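The compounds below may be only part of what the source reports. "The series", "measured", "known", "first", "only" and "open" are said of these compounds alone.

Measured so far in an ADME assay on microsomes from liver (Homo sapiens) for metabolic stability; on this read-out higher numbers stand for a longer-lived compound and lower numbers for a shorter-lived compound:
- compound 1 `COc1ccc(C2=Nc3c(C(C)(C)C)nn(CCCO)c3C(=O)NC2)cc1-c1ccccc1F`: 0.8 h
- compound 2 `COc1ccc(C2=Nc3c(C(C)(C)C)nn(CCCO)c3C(=O)NC2)cc1-c1cnc(N(C)C)cc1C`: 0.7 h

Compound 1 holds the higher of the two numbers, but its step to compound 2, a 1.1-fold lower number from compound 1 to compound 2 (0.06 log units; within the scatter), stays within the scatter, so the two half-lives cannot be told apart.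

Compound 3 `COc1ccc(C2=Nc3c(C(C)(C)C)nn(CCCO)c3C(=O)NC2)cc1-c1ccc(C(=O)O)cc1` is the next compound of the series to be measured. It differs from compound 1 as follows: 4-carboxyphenyl in place of 2-fluorophenyl on an aromatic carbon. Among the compounds with values here, the one step measured so far, a 1.1-fold lower number from compound 1 to compound 2 (0.06 log units; within the scatter), concerns an exchange at the same aromatic carbon and left the half-life essentially unchanged. Within the data shown here, no measured step covers a 4-carboxyphenyl group, so the only guide is that one exchange at this carbon did not move the number beyond the scatter.

The step from compound 1 to compound 3 in this assay is therefore expected to be small, a 1.1-fold higher number from compound 1 to compound 3 (0.05 log units; within the scatter), with no direction beyond the scatter. For compound 3 a half-life of 0.9 h is estimated, within a range of 0.4 h to 2 h.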

Compound 3, half-life: 2 h
Beside the measured number, compound 3's estimate is 2.2-fold (0.35 log units) below it, within the range that was stated.
By their numbers in this assay, from the lowest: compounds 2 and 1 (each within the scatter of the next); then compound 3.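

In this assay, this aromatic carbon, ortho to a methoxy group, proves able to move the half-life: 4-carboxyphenyl in place of 2-fluorophenyl gives a 2.5-fold higher number from compound 1 to compound 3 (0.40 log units; beyond the scatter), a modest step, and in place of 6-(dimethylamino)-4-methylpyridin-3-yl it gives a 2.9-fold higher number from compound 2 to compound 3 (0.46 log units; beyond the scatter), also modest. The earlier exchange at this carbon stayed within the scatter, so two quite different groups there could not be told apart, whereas 4-carboxyphenyl now stands clear of both. Nothing available explains this gain.

The compounds shown leave open whether the gain belongs to the carboxylic acid itself or would hold with a methyl ester, a primary amide or a tetrazole on the same phenyl ring. They also leave open whether an unsubstituted phenyl group would sit with compound 1 or with compound 3.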